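The compounds below may be only part of what the source reports. "The series", "measured", "known", "first", "only" and "open" are said of these compounds alone.

Among the compounds with values here, in a functional assay (aorta) with Rattus norvegicus as the target (on this read-out higher numbers stand for weaker inhibition and lower numbers for stronger inhibition), compound 1 (`CC1(C)Oc2ccc(C#N)cc2[C@@H](/N=C(\NC#N)Nc2ccc(Cl)cc2)[C@@H]1O`) gives 1800 nM as the only numeric reading. Compound 2 (`CCOC(=O)CN(c1ccccc1)C1c2cc(C#N)ccc2OC(C)(C)C1O`) reads > 30000 nM in this series, and that is a limit. Compound 3 (`CCOC(=O)CN(c1ccccc1)[C@H]1c2cc(C#N)ccc2OC(C)(C)[C@@H]1O`) reads > 30000 nM and so stands only at a limit too. Within the data shown here, compound 4 (`CCOC(=O)CN(c1ccccc1)[C@@H]1c2cc(C#N)ccc2OC(C)(C)[C@H]1O`) comes from compound 3 through the two compounds have the same atoms and bonds and differ only in configuration as drawn: 2 of 2 stereo elements differ (all stereocentres are inverted: mirror images); a stereocentre at a saturated ring carbon is drawn S in compound 3 and R in compound 4; a stereocentre at a saturated ring carbon is drawn R in compound 3 and S in compound 4 as the sole change. Among the measured compounds shown here, the one measured step bearing on this is a step that the two limits leave unreadable from compound 2 to compound 3 and it offers no size to carry over. For the measured compounds named here, with the limit of > 30000 nM in this assay, at which 2 of the 3 values shown sit, as the only guide for compound 3, no direction can be assigned in this assay and no shift beyond the scatter is expected, so the expected step is a number no higher from compound 3 to compound 4 (the limit leaves the size open) in this reading. Compound 4 is estimated at 30000 nM (range 12000 nM to 60000 nM) and will probably be reported as a limit again.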

Compound 4, half-maximal inhibitory concentration: > 30000 nM
Compound 4 ended at the assay's limit; the forecaster's own chance of this, stated with the estimate: 85%; the middle value lies on the limit itself.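

In this assay, within the data shown here, compound 4 gives > 30000 nM, which is a limit, so no step among compound 2, compound 3 and compound 4 can be read. On these data alone, whether the mirror images compound 3 and compound 4 differ at all remains open.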